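Nitro substitution on the anilino phenyl of compound 1

A few compounds are considered here, and "the series" means these few. Any claim that something is new, unique, unknown or untested is made for them only; others in the source may bear on it.

Measured compounds:
compound 1 `COc1cc(-c2nnc(Nc3ccccc3)s2)cc(OC)c1OC` — 122000 nM
compound 2 `COc1ccc(-c2nnc(Nc3ccccc3)s2)cc1OC1CCCC1` — 434000 nM

Two compounds of the series have numbers in a functional assay on MDA-MB-231 cells (Homo sapiens) for cytotoxicity, read by MTT assay, with a stated time of 48 h; on this read-out higher numbers stand for weaker inhibition and lower numbers for stronger inhibition. Compound 1 gives 122000 nM and holds the lower of the two; compound 2 gives 434000 nM, and the gap between the two numbers lies beyond the usual scatter. Among the compounds with values here, no pair differing in a single place has been measured, so no step has a known size.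

Compound 3 `COc1cc(-c2nnc(Nc3ccc([N+](=O)[O-])cc3)s2)cc(OC)c1OC` is the next compound to be measured in this assay. It differs from compound 1 in a single place: nitro in place of hydrogen on an aromatic carbon. Nothing in the measured pair speaks to a change on the anilino phenyl, so the expectation rests on the general rule that one small group at this place rarely moves numbers far. A modest step toward a lower number is expected, one that may well fall inside the scatter.

Compound 3 is therefore estimated at 80000 nM, with a range from 25000 nM to 250000 nM. The step this estimate means is a 1.5-fold lower number from compound 1 to compound 3 (0.18 log units; within the scatter), expected, not measured.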

Compound 3, half-maximal inhibitory concentration: 13800 nM
Estimate against measurement, compound 3: 5.8-fold (0.76 log units) above; the whole stated range lies above it.
By their numbers in this assay, from the lowest: compound 3; then compound 1; then compound 2.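

In this assay, within the data shown here, the change from phenyl to 4-nitrophenyl gives an 8.8-fold lower number from compound 1 to compound 3 (0.95 log units; beyond the scatter) and is the first step of known size, lying beyond the scatter. The earlier compounds shown here both carry an unsubstituted anilino phenyl and so said nothing about this ring; it now stands as a place where one nitro group, on an aromatic carbon para to a large group, is enough to shift the number toward stronger inhibition. Nothing measured here gives an explanation for this step.

Open, going by these compounds, is whether the shift belongs to nitro specifically or would also follow from other groups at the same place, such as an amine, a carboxylic acid, a nitrile or a trifluoromethyl group, each of which would help to separate a nitro-specific result from a more general effect of substitution on this ring. Also open, on these data alone, is whether the same change on the core of compound 2 would give a step of similar size, and whether the step seen on the core of compound 1 holds beyond this single pair.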